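The source may report more compounds than this note shows. Statements on the series, on what has been measured and on what is new or still open speak of the compounds shown alone.

Measured so far:
- compound 1 `COc1ccc(Br)cc1CCc1c(F)cccc1C(=O)/N=C(\N)NCCC1CCCCC1`: 2600 nM
- compound 2 `CCCC/N=C(/N)NC(=O)c1cccc(F)c1CCc1cc(Br)ccc1OC`: 920 nM

In an assay for binding affinity to Melanocortin receptor 4 (Homo sapiens) (a higher number here means a weaker inhibitor, a lower number a stronger inhibitor), compound 2 gives 920 nM, the lowest of the two numbers; compound 1 gives 2600 nM, a higher number, and the gap between the two lies beyond the usual scatter. For the measured compounds named here, no step between two measured compounds differing in a single place is available, so this pair shows only what its two values show.

Compound 3 `CCN(CC)CCCC(C)/N=C(/N)NC(=O)c1cccc(F)c1CCc1cc(Br)ccc1OC` has not yet been measured in this assay. It differs from compound 2 in one place: 4-(diethylamino)-1-methylbutyl in place of butyl on a double-bonded nitrogen. The side chain on the double-bonded nitrogen grows from butyl to 4-(diethylamino)-1-methylbutyl, which brings in one nitrogen and a branching methyl, while the rest of the molecule stays as in compound 2.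

Going by the values given here, with no comparable step among the measured compounds, the account can only expect a modest change in this assay from compound 2 to compound 3, most likely a small improvement but possibly none beyond the scatter. The estimated step is a 1.5-fold lower number from compound 2 to compound 3 (0.19 log units; within the scatter). Compound 3 is expected to give about 600 nM in this assay, within a range from 150 nM to 2500 nM.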

Compound 3, inhibition constant: 4.3 nM
Estimate against measurement, compound 3: 140-fold (2.14 log units) above; measured number outside the range, below it.
By their numbers in this assay, from the lowest: compound 3; then compound 2; then compound 1.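

In this assay the replacement of butyl by 4-(diethylamino)-1-methylbutyl on the double-bonded nitrogen brings a 210-fold lower number from compound 2 to compound 3 (2.33 log units; beyond the scatter), so this position can move the number by far more than the two earlier compounds suggested. Those two, whose side chains hold only carbon, lay much closer together, with compound 2 at 920 nM and compound 1 at 2600 nM, and they gave no sign that a chain carrying a diethylamino group would reach a different range altogether. Nothing measured here accounts for the size of this step.

The step also changes several things at once, adding the chain length, the branching methyl and the nitrogen together, so the compounds shown cannot assign the gain to any one of them. Open questions are whether a 4-(diethylamino)butyl chain without the methyl would keep the gain, and whether a dimethylamino group, a pyrrolidine ring, a primary amine or a hydroxyl group at the chain end, or a shorter chain between that end and the double-bonded nitrogen, would give a similar number.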